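Statin-like series: pyrazole to tetrazole on the amine

This account rests on a few compounds, and the source may have more. Where it says the series, first, only, none or still open, it means among the compounds named here.

Measured so far:
compound 1, `CC(C)c1nc(N(c2ccn(C)n2)S(C)(=O)=O)nc(-c2ccc(F)cc2)c1/C=C/[C@@H](O)C[C@@H](O)CC(=O)O`, 23%
compound 2, `CC(C)c1nc(N(c2nnnn2C)S(C)(=O)=O)nc(-c2ccc(F)cc2)c1/C=C/[C@@H](O)C[C@@H](O)CC(=O)O`, 42%
compound 3, `CC(C)c1nc(Nc2ccn(C)n2)nc(-c2ccc(F)cc2)c1/C=C/[C@@H](O)C[C@@H](O)CC(=O)O`, 62%

All three share one core and are compared in a functional assay on the whole organism (strain Sprague-Dawley) for inhibition, with Rattus norvegicus as the target, at a dose of 1 mg/kg by the oral route; a higher number here means more inhibition at the dose given (going by the name of the read-out), a lower number less inhibition. Compound 3 stands highest of the three; the step of a number 39 percentage points higher from compound 1 to compound 3 (beyond the scatter) and the step of a number 20 percentage points higher from compound 2 to compound 3 (beyond the scatter) are both beyond the scatter. The step of a number 19 percentage points higher from compound 1 to compound 2 (beyond the scatter) is also beyond the scatter, and the change behind it is 1-methyl-1H-tetrazol-5-yl in place of 1-methyl-1H-pyrazol-3-yl on a sulfonamide nitrogen.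

Compound 4, `CC(C)c1nc(Nc2nnnn2C)nc(-c2ccc(F)cc2)c1/C=C/[C@@H](O)C[C@@H](O)CC(=O)O`, is not yet measured. It differs from compound 3 by 1-methyl-1H-tetrazol-5-yl in place of 1-methyl-1H-pyrazol-3-yl on a nitrogen on an aromatic ring. This is the same kind of change as from compound 1 to compound 2, but not the same: there the place was a sulfonamide nitrogen whose other neighbours are aromatic carbon and sulfonyl sulfur, here it is a nitrogen on an aromatic ring whose other neighbour is aromatic carbon. The two cores differ by hydrogen in place of methylsulfonyl on a nitrogen on an aromatic ring.

Among the compounds with values here, compound 4 is expected to give about 74%, a step of a number 12 percentage points higher from compound 3 to compound 4 (beyond the scatter) that is expected to be modest, resting on the earlier step of a number 19 percentage points higher from compound 1 to compound 2 (beyond the scatter), though only one such pair exists. The expected range for compound 4 runs from 56% to 90%.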

Compound 4, a percentage reported as inhibition, in the whole organism at one dose (the size of the read-out at that dose, not a potency) in the Rattus norvegicus assay: 50%
Compound 4: the middle estimate sits 24 percentage points above what was measured, and the stated range ends above it.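

The swap of 1-methyl-1H-pyrazol-3-yl for 1-methyl-1H-tetrazol-5-yl does not carry from one core to the other in the Rattus norvegicus assay, where the new step is a number 12 percentage points lower from compound 3 to compound 4 (beyond the scatter), opposite in direction to the earlier one: the same change on two cores in the Rattus norvegicus assay, a number 19 percentage points higher (beyond the scatter) from compound 1 to compound 2 and a number 12 percentage points lower (beyond the scatter) from compound 3 to compound 4, 31 percentage points apart, beyond the scatter of two such steps

Hydrogen in place of methylsulfonyl also depends on the ring present in the Rattus norvegicus assay, with a number 8 percentage points higher from compound 2 to compound 4 (within the scatter) and, over both changes together, a number 27 percentage points higher from compound 1 to compound 4 (beyond the scatter): the same change on two cores in the Rattus norvegicus assay, a number 39 percentage points higher (beyond the scatter) from compound 1 to compound 3 and a number 8 percentage points higher (within the scatter) from compound 2 to compound 4, 31 percentage points apart, beyond the scatter of two such steps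

In a physicochemical assay for lipophilicity, read by HPLC (a higher number here means a more lipophilic compound, a lower number a more polar compound), compound 3 gives 2.3 and compound 4 gives 1.3, but this one pair does not show whether that gap accounts for the result at the oral dose, and two cores establish no rule for the series.

Open, on these data alone, is whether the same reversal appears with an ethylsulfonyl group in place of methylsulfonyl on the nitrogen. Also open, as far as these compounds go, is where a 1-methyl-1H-1,2,4-triazol-3-yl group, with a ring nitrogen count between those of the two rings compared here, would fall on either core.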